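From (phenylsulfonyl)amino to ((4-fluorophenyl)carbonyl)oxy: expected half-life

The compounds below may be only part of what the source reports. "The series", "measured", "known", "first", "only" and "open" are said of these compounds alone.

Three compounds have been measured in an ADME assay on cells (Hepatocyte, Mus musculus) for metabolic stability; a lower number here means that the compound disappears faster, a higher number that the compound lasts longer:
- compound 1, `O=c1cc(N2CCN(CC3CCC(NS(=O)(=O)c4ccccc4)CC3)CC2)sc2c([N+](=O)[O-])cc(C(F)(F)F)cc12`: > 1.55 h.
- compound 2, `O=C(OC1CCC(CN2CCN(c3cc(=O)c4cc(C(F)(F)F)cc([N+](=O)[O-])c4s3)CC2)CC1)c1ccncc1`: 0.0817 h.
- compound 3, `O=C(OC1CCC(CN2CCN(c3cc(=O)c4cc(C(F)(F)F)cc([N+](=O)[O-])c4s3)CC2)CC1)c1ccc(C(F)(F)F)cc1`: 0.278 h.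

Going by these compounds, for compound 1 the result is only a limit of this assay, not a number, so its true value is unknown beyond that (the limit of > 1.55 h in this assay, at which 1 of the 3 values shown sits). Compound 4, `O=C(OC1CCC(CN2CCN(c3cc(=O)c4cc(C(F)(F)F)cc([N+](=O)[O-])c4s3)CC2)CC1)c1ccc(F)cc1`, has not yet been measured. It differs from compound 1 in one place: ((4-fluorophenyl)carbonyl)oxy in place of (phenylsulfonyl)amino on a saturated ring carbon.

Within the data shown here, two measured steps bear on this change. The step of an at least 18-fold lower number from compound 1 to compound 2 (1.27 log units; beyond the scatter) shows that replacing the (phenylsulfonyl)amino group with an aromatic ester brought a large drop in this assay. The step of a 3.4-fold higher number from compound 2 to compound 3 (0.53 log units; beyond the scatter) shows that the aromatic ring on the carbonyl carbon matters as well, with 4-(trifluoromethyl)phenyl giving a modestly higher number than pyridin-4-yl. Among the measured compounds shown here, a 4-fluorophenyl ring has no measured counterpart here, so compound 4 is expected to fall near compounds 2 and 3 rather than near compound 1. For compound 4 a large drop is therefore expected, an at least 7.7-fold lower number from compound 1 to compound 4 (0.88 log units; beyond the scatter). The estimate for compound 4 in this assay is 0.2 h, with a range from 0.07 h to 0.6 h.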

Compound 4, half-life: 0.0817 h
The estimate for compound 4 lay 2.4-fold (0.39 log units) above the measured number; the range from low to high includes it.
By their numbers in this assay, from the lowest: compounds 2 and 4 (each within the scatter of the next); then compound 3. At a limit, above all of these: compound 1.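

In this assay, a second ester gives an at least 18-fold lower number from compound 1 to compound 4 (1.27 log units; beyond the scatter), so the large drop on leaving (phenylsulfonyl)amino is not tied to the pyridin-4-yl ring. Going by these compounds, the true size of that step stays unknown, as the result for compound 1 is a limit: the limit of > 1.55 h in this assay, at which 1 of the 4 values shown sits. Among the esters, the ring change gives no change at the digits printed from compound 2 to compound 4 (within the scatter), while the swap on the aromatic carbon gives a 3.4-fold lower number from compound 3 to compound 4 (0.53 log units; beyond the scatter), so a ring of carbon only does not by itself give the higher number, and among these three esters only the 4-(trifluoromethyl)phenyl ester stands apart.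

Still open, on these data alone, is whether an amide, with its carbonyl joined through nitrogen to the saturated ring, would stay with the sulfonamide or fall with the esters. Also open, as far as these compounds go, is how a chloro or methoxy group on the phenyl ring would compare with fluoro and trifluoromethyl.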